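This account rests on a few compounds, and the source may have more. Where it says the series, first, only, none or still open, it means among the compounds named here.

In a functional assay on A2780 cells (Homo sapiens) for inhibition, read by sulforhodamine B assay, with a stated time of 72 h (a lower number here means a stronger inhibitor, a higher number a weaker inhibitor), compound 1 (`O=C(NCc1ccc(S(=O)(=O)c2cccc(F)c2)cc1)c1cc2cnccc2[nH]1`) gives 11 nM and compound 2 (`O=C(NCc1ccc(S(=O)(=O)c2cccc(C(F)(F)F)c2)cc1)c1cc2cnccc2[nH]1`) gives 3 nM as the lower of the two numbers, which makes compound 2 the stronger inhibitor so far. Within the data shown here, the only measured step is a 3.7-fold lower number from compound 1 to compound 2 (0.56 log units; beyond the scatter) and it concerns the trifluoromethyl group, which compound 3 (`O=C(NCc1ccc(S(=O)(=O)c2cccc(C(F)(F)F)c2)cc1)c1cc2ccncc2o1`) keeps.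

Compound 3 differs from compound 2 in another place, the group on the carbonyl carbon: a group of 9 heavy atoms (7 carbon, 1 nitrogen, 1 oxygen; one five-membered aromatic ring with 1 hetero atom, one six-membered aromatic ring with 1 hetero atom) in place of a group of 9 heavy atoms (7 carbon, 2 nitrogen; one five-membered aromatic ring with 1 hetero atom, one six-membered aromatic ring with 1 hetero atom), on a carbonyl carbon is the full change. Among the measured compounds shown here, no measured step touches that group, so the size of the one known step cannot be carried over to it, and the data offer no direct guide. Nothing measured points to a large shift in this assay either, so the working expectation is a small move towards a higher number, held with a wide margin of doubt. The expected size of the change is a 2.0-fold higher number from compound 2 to compound 3 (0.30 log units; within the scatter) and it may well stay within the scatter. For compound 3 the estimated value is 6 nM (expected range 1.5 nM to 30 nM).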

Compound 3, half-maximal inhibitory concentration: 3 nM
Compound 3: the middle estimate sits 2.0-fold (0.30 log units) above what was measured; low and high end bracket the measured number.
By their numbers in this assay, from the lowest: compounds 2 and 3 (each within the scatter of the next); then compound 1.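

On a carbonyl carbon whose other neighbour is an amide-type nitrogen, the group with 7 carbon and 1 nitrogen and 1 oxygen can stand in for the group with 7 carbon and 2 nitrogen, giving in this assay no change at the digits printed from compound 2 to compound 3 (within the scatter) while the trifluoromethyl group stays in place. Among these compounds, the earlier pair varied only the far end of the molecule, so this is the first sign that this second position can also be changed without a step beyond the scatter, at least in this one pair. The count of hydrogen-bond donors in the group falls from 1 to 0 and the count of acceptors rises from 1 to 2 with no readable effect on the number, although nothing measured here gives a cause for that result.

On these data alone, whether the same swap would read the same way with fluoro in place of trifluoromethyl stays open, since a single pair cannot show that the two changes act independently. As far as these compounds go, how far this position can stretch is also open, for instance whether a group carrying a carboxylic acid or an amine on the carbonyl carbon would keep a number in this range.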